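The source may hold more compounds than are shown below. What is called first, only, known or untested is meant among the compounds shown, and "the series" means these compounds.

Measured compounds:
compound 1, `CC(C(=O)N1CCN(c2ccc(Cl)cc2)CC1)N1C(=O)CCC1=O`, 0%
compound 2, `CCC(C(=O)N1CCN(c2cccc(OC)c2)CC1)N1C(=O)CCC1=O`, 0%

In a functional assay on the whole organism (strain Swiss) with Mus musculus as the target, in the maximal electroshock model, with a stated time of 1 h, at a dose of 300 mg/kg by the intraperitoneal route (a higher number here means a stronger effect of the compound at the dose given, a lower number a weaker effect), compound 1 gives 0%, and compound 2 gives 0%, so compound 1 stands level with compound 2 at the digits shown, within the scatter. Compound 3, `CC(C(=O)N1CCN(c2ccc(F)cc2)CC1)N1C(=O)CCC1=O`, is not yet measured. It differs from compound 1 by a single change: fluoro in place of chloro on an aromatic carbon. Going by the values given here, no step between measured compounds is available to size this change. Since compound 1 shows no effect at the dose used, and compound 2 likewise, the step of no change at the digits printed from compound 1 to compound 3 (within the scatter) is expected to be none beyond the scatter. For compound 3 the expected activity is 0%, in a range from 0% to 20%.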

Compound 3, a percentage reported as activity, at one dose (the size of the read-out at that dose, not a potency): 25%
For compound 3 the middle estimate is 25 percentage points below the measured one; measured number outside the range, above it.
By their numbers in this assay, from the lowest: compounds 1 and 2 (each within the scatter of the next); then compound 3.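

In this assay, fluoro in place of chloro on an aromatic carbon gives a number 25 percentage points higher from compound 1 to compound 3 (beyond the scatter) at the one dose tested. Going by these compounds alone, this is the first sign that the read-out responds to this position, para to a large group, which the level values of compounds 1 and 2 could not show. It also shows that exchanging one halogen for another is enough to produce a difference here, and nothing measured bears on why. The compounds shown leave open whether a nitrile or a trifluoromethyl group at this position would change the read-out further. They also leave open whether the fluoro step would hold with a longer chain elsewhere on the core of compound 1.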